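Lengthening an ether chain in a cytotoxicity series

This account rests on a few compounds, and the source may have more. Where it says the series, first, only, none or still open, it means among the compounds named here.

Measured compounds:
compound 1, `CCC(=O)OCc1c(F)c(N)c2c(=O)cc(-c3ccc(N)c(F)c3)oc2c1F`, 69000 nM in a functional assay on HeLa cells (Homo sapiens) for cytotoxicity, read by neutral red uptake, with a stated time of 3 days; a higher number here means a weaker inhibitor, a lower number a stronger inhibitor
compound 2, `CCCCCC(=O)OCc1c(F)c(N)c2c(=O)cc(-c3ccc(N)c(F)c3)oc2c1F`, 34000 nM
compound 3, `CCCOCc1c(F)c(N)c2c(=O)cc(-c3ccc(N)c(F)c3)oc2c1F`, 78000 nM

Within this set, a 2.0-fold lower number from compound 1 to compound 2 (0.31 log units; beyond the scatter), a 1.1-fold higher number from compound 1 to compound 3 (0.05 log units; within the scatter) and a 2.3-fold higher number from compound 2 to compound 3 (0.36 log units; beyond the scatter). Compound 4, `CCCCCCOCc1c(F)c(N)c2c(=O)cc(-c3ccc(N)c(F)c3)oc2c1F`, has not been measured. It differs from compound 3 by propyl in place of hydrogen on a saturated chain carbon, three bonds along the chain from an oxygen on a saturated carbon. The same kind of change separates compound 1 from compound 2, (propyl in place of hydrogen on a saturated chain carbon, two bonds along the chain from a carbonyl carbon), though there the place is two bonds along the chain from a carbonyl carbon, whereas in compound 4 it is three bonds along the chain from an oxygen on a saturated carbon. The two cores differ by propyl in place of propanoyl on an oxygen on a saturated carbon. Because a 2.0-fold lower number from compound 1 to compound 2 (0.31 log units; beyond the scatter), a step of similar modest size is expected here, a 2.0-fold lower number from compound 3 to compound 4 (0.29 log units; within the scatter), resting on that single earlier pair. Compound 4 is therefore estimated at 40000 nM, between 20000 nM and 90000 nM.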

Compound 4, half-maximal inhibitory concentration: > 100000 nM
Compound 4: a limit, no number; the forecaster's own chance of this, stated with the estimate: 15%; middle value at least 2.5-fold (0.39 log units) away from the limit.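

In this assay compound 4 gives > 100000 nM, which is a limit of the assay and not a number. The limit allows only minimum sizes for the new steps: an at least 1.2-fold higher number from compound 3 to compound 4 (0.10 log units; that floor lies within the scatter), an at least 1.4-fold higher number from compound 1 to compound 4 (0.16 log units; that floor lies within the scatter) and an at least 2.9-fold higher number from compound 2 to compound 4 (0.46 log units; beyond the scatter). Propyl in place of hydrogen therefore cannot be said either to carry over from one core to the other or to behave differently on the two: the same change on two cores in this assay, a 2.0-fold lower number (0.31 log units; beyond the scatter) from compound 1 to compound 2 and an at least 1.2-fold higher number (0.10 log units; that floor lies within the scatter) from compound 3 to compound 4; the limit leaves it open whether they differ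

As far as these compounds go, the true value of compound 4 stays open, and with it the real size of its steps. Also open, from the compounds shown here alone, is how a longer chain, or a chain carrying an amine, would read in this assay.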